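Aryl variation on the piperazine nitrogen: compound 4

A few compounds are considered here, and "the series" means these few. Any claim that something is new, unique, unknown or untested is made for them only; others in the source may bear on it.

Measured so far:
- compound 1 `S=c1oc(-c2ccc3c(c2)OCCO3)nn1CN1CCN(c2cccc(Cl)c2Cl)CC1`: 22600 nM
- compound 2 `S=c1oc(-c2ccc3c(c2)OCCO3)nn1CN1CCN(c2ccccc2)CC1`: > 50000 nM
- compound 3 `Fc1ccc(N2CCN(Cn3nc(-c4ccc5c(c4)OCCO5)oc3=S)CC2)cc1`: > 50000 nM

For the measured compounds named here, in a functional assay on BGC-823 cells (Homo sapiens) for antiproliferative activity, read by MTT assay, with a stated time of 48 h (on this read-out higher numbers stand for weaker inhibition and lower numbers for stronger inhibition), compound 1 gives 22600 nM, the only numbered value in the set. For compound 2 the result is a limit, > 50000 nM. For compound 3 the result is likewise a limit, > 50000 nM. Compound 3 therefore stands at the limit of this assay, and the same holds for (the limit of > 50000 nM in this assay, at which 2 of the 3 values shown sit).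

The readable steps are an at least 2.2-fold higher number from compound 1 to compound 2 (0.34 log units; beyond the scatter) and an at least 2.2-fold higher number from compound 1 to compound 3 (0.34 log units; beyond the scatter); both open-ended. The step that the two limits leave unreadable from compound 2 to compound 3 cannot be sized.

Compound 4 `S=c1oc(-c2ccc3c(c2)OCCO3)nn1CN1CCN(c2ccccc2Cl)CC1` differs from compound 3 as follows: 2-chlorophenyl in place of 4-fluorophenyl on an amine nitrogen in a ring. Going by the values given here, the entering 2-chlorophenyl shares a chlorine with the 2,3-dichlorophenyl of compound 1, whose value 22600 nM is the only measured number. Since the two steps away from compound 1 were each at least modest, the step is expected to run downward, an at least 1.2-fold lower number from compound 3 to compound 4 (0.09 log units; that floor lies within the scatter), with a real chance the assay again reports only a limit. The estimate for compound 4 in this assay is 40000 nM, from 15000 nM to 100000 nM.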

Compound 4, half-maximal inhibitory concentration: > 50000 nM
Compound 4: only a limit was reported; the forecaster's own chance of this, stated with the estimate: 50%; at least 1.2-fold (0.09 log units) between middle value and limit.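

In this assay compound 4 gives a limit (> 50000 nM) and not a number. Hydrogen in place of one chloro on the 2,3-dichlorophenyl gives an at least 2.2-fold higher number from compound 1 to compound 4 (0.34 log units; beyond the scatter) and this is the only readable step that changes a single chloro, so the one chlorine of the 2-chlorophenyl, on the amine nitrogen in the ring, does not hold the numbered value of the dichloro compound. The steps among compound 2, compound 3 and compound 4 cannot be read, so phenyl, 4-fluorophenyl and 2-chlorophenyl take no order, and the series now rests on one number and a shared ceiling: the limit of > 50000 nM in this assay, at which 3 of the 4 values shown sit.

Open, from the compounds shown here alone, is whether a 3-chlorophenyl on the same nitrogen would keep a numbered value, which would show whether the second chlorine alone carries the measured result or the two are needed together. Also open, going by these compounds, is whether the effect belongs to chlorine at all, which a 2,3-dimethylphenyl or a 2,3-dibromophenyl at this place would begin to separate.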